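This account rests on a few compounds, and the source may have more. Where it says the series, first, only, none or still open, it means among the compounds named here.

Measured compounds:
compound 1 `Cc1ccccc1COc1ccc(-c2cc(CN3CCN(Cc4ccc(C(F)(F)F)cc4)CC3)no2)cc1` gives 3700 nM
compound 2 `Cc1cc(C)cc(COc2ccc(-c3cc(CN4CCN(Cc5ccc(C(F)(F)F)cc5)CC4)no3)cc2)c1` gives 1600 nM
compound 3 `Fc1ccccc1COc1ccc(-c2cc(CN3CCN(Cc4ccc(C(F)(F)F)cc4)CC3)no2)cc1` gives 3000 nM

All three values come from a functional assay on MCF7 cells (Homo sapiens) for antiproliferative activity, read by sulforhodamine B assay, with a stated time of 72 h; on this read-out lower numbers stand for stronger inhibition and higher numbers for weaker inhibition. Compound 3 sits within the scatter of both neighbours: the step of a 1.2-fold lower number from compound 1 to compound 3 (0.09 log units; within the scatter) and the step of a 1.9-fold higher number from compound 2 to compound 3 (0.27 log units; within the scatter) are each inside the usual spread, so no order among these three can be read from compound 3 itself. For the measured compounds named here, the only step that reaches beyond the scatter is a 2.3-fold lower number from compound 1 to compound 2 (0.36 log units; beyond the scatter).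

Compound 4 `COc1cccc(COc2ccc(-c3cc(CN4CCN(Cc5ccc(C(F)(F)F)cc5)CC4)no3)cc2)c1` is not yet measured. It differs from compound 3 by 3-methoxyphenyl in place of 2-fluorophenyl on a saturated chain carbon bound to an oxygen on an aromatic ring. The bearing steps are those that also change the aryl group on the saturated chain carbon bound to an oxygen on an aromatic ring: a 1.2-fold lower number from compound 1 to compound 3 (0.09 log units; within the scatter), a 1.9-fold higher number from compound 2 to compound 3 (0.27 log units; within the scatter) and a 2.3-fold lower number from compound 1 to compound 2 (0.36 log units; beyond the scatter). Two of these lie within the scatter and the third is only modest, so for this assay a step from compound 3 to compound 4 no larger than the scatter, in either direction, is expected: a 1.2-fold lower number from compound 3 to compound 4 (0.08 log units; within the scatter). Compound 4 is therefore estimated at 2500 nM, with a range from 1000 nM to 6000 nM.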

Compound 4, half-maximal inhibitory concentration: 2000 nM
Beside the measured number, compound 4's estimate is 1.3-fold (0.10 log units) above it; the range from low to high includes it.
By their numbers in this assay, from the lowest: compounds 2, 4, 3 and 1 (each within the scatter of the next, the first and the last beyond it).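

In this assay, 3-methoxyphenyl on a saturated chain carbon bound to an oxygen on an aromatic ring gives a 1.5-fold lower number from compound 3 to compound 4 (0.18 log units; within the scatter) and a 1.3-fold higher number from compound 2 to compound 4 (0.10 log units; within the scatter) and a 1.9-fold lower number from compound 1 to compound 4 (0.27 log units; within the scatter) so all three steps stay within the scatter. For the compounds shown here, the exchange of 2-fluorophenyl for 3-methoxyphenyl adds 1 hydrogen-bond acceptor to a position that had 0 there and still produces no step beyond the scatter, and compound 4 does not separate from either compound 1 or compound 2, the one pair printed as beyond the scatter. No measurement is at hand that would explain these numbers.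

The compounds shown leave open whether an amine or a carboxylic acid on this aryl group would give a step beyond the scatter. As far as these compounds go, a longer chain in place of the saturated chain carbon also remains open.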